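Extending an Alkenyl Chain on Compound 3

The compounds below may be only part of what the source reports. "The series", "measured", "known", "first", "only" and "open" are said of these compounds alone.

- compound 1 `C=CCCCCOc1ccc(C)cc1-c1cnc(OCCC=C)n1C`: 33000 nM
- compound 2 `C=CCCCCOc1ccc(OC)cc1-c1cnc(OCCC=C)n1C`: 67000 nM
- compound 3 `C=CCCCCOc1ccccc1-c1cnc(OCCCC=C)n1C`: 5000 nM

All three compounds were tested in a functional assay on U-373MG ATCC cells (Homo sapiens) for inhibition, read by colorimetric assay and MTT assay, with a stated time of 72 h; a lower number here means a stronger inhibitor, a higher number a weaker inhibitor. There, compound 3 gives 5000 nM, the lowest number of the three and clearly apart from the other two.

The next compound is compound 4 `C=CCCCCCOc1ncc(-c2ccccc2OCCCCC=C)n1C`, which has not yet been measured. It differs from compound 3 by but-3-en-1-yl in place of vinyl on a saturated chain carbon, three bonds along the chain from an oxygen on an aromatic ring. The same difference can also be read as pent-4-en-1-yl to hept-6-en-1-yl.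

Within the data shown here, only one single-place step has been measured, a 2.0-fold higher number from compound 1 to compound 2 (0.31 log units; beyond the scatter). It is modest, and it concerns methoxy in place of methyl on an aromatic carbon, which is a different kind of change. Among the measured compounds shown here, no measured step alters this chain alone, so the data give no direction for the change. Compound 3 also differs from compound 1 and compound 2 in more than one place, so their gaps cannot be assigned to the chain.

The expected outcome in this assay is therefore no clear shift, with wide uncertainty on both sides. The expected step is a 1.2-fold higher number from compound 3 to compound 4 (0.08 log units; within the scatter). The estimate for compound 4 is 6000 nM, within an expected range of 1500 nM to 30000 nM.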

Compound 4, half-maximal inhibitory concentration: 76000 nM
For compound 4 the middle estimate is 13-fold (1.10 log units) below the measured one; measured number above the stated range.
By their numbers in this assay, from the lowest: compound 3; then compound 1; then compounds 2 and 4 (each within the scatter of the next).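

Among these compounds, this is the first measured change to this chain alone, and it shows that the chain's length at this position matters. Putting but-3-en-1-yl in place of vinyl, three bonds along the chain from an oxygen on an aromatic ring, turns pent-4-en-1-yl into hept-6-en-1-yl, and in this assay this gives a 15-fold higher number from compound 3 to compound 4 (1.18 log units; beyond the scatter) as a large step beyond the scatter. That step is well above the modest 2.0-fold higher number from compound 1 to compound 2 (0.31 log units; beyond the scatter) seen in the same assay for methoxy in place of methyl on an aromatic carbon, so among the changes measured so far, the chain extension moves the number most, but no measurement shown here explains why.

A single step cannot show whether the number climbs gradually with each added carbon or jumps sharply beyond a certain length, and a hex-5-en-1-yl chain at this position would help to separate those two readings. On these data alone, it also remains open whether a shorter allyl chain would give a lower number than compound 3 does, and whether a saturated chain or one ending in an amine or a carboxylic acid would behave like these alkenyl chains.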